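Methoxy removal on a fused bromoaromatic core, tracked in cells

This account rests on a few compounds, and the source may have more. Where it says the series, first, only, none or still open, it means among the compounds named here.

Measured compounds:
Compound 1 `COC(=O)C1=C(N)Oc2c(OC)cc(Br)cc2C1CC(=O)c1ccc(Br)cc1`: 50.2%
Compound 2 `COC(=O)C1=C(N)Oc2ccc(Br)cc2C1CC(=O)c1ccc(Br)cc1`: 72.5%
Compound 3 `COc1cccc(C(=O)CC2C(C#N)=C(N)Oc3c(OC)cc(Br)cc32)c1`: 55.9%

In a functional assay on MCF7 cells (Homo sapiens) for antiproliferative activity, read by sulforhodamine B assay, with a stated time of 72 h, tested at 10 uM (on this read-out lower numbers stand for a stronger effect and higher numbers for a weaker effect at the one concentration tested), compound 1 gives 50.2% and compound 2 gives 72.5%. The two differ by one change, (hydrogen in place of methoxy on an aromatic carbon), and the step is a number 22.3 percentage points higher from compound 1 to compound 2 (beyond the scatter). Compound 3 gives 55.9% in this assay; how its core differs from the core of compound 1 is not broken down here.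

Compound 4 `COc1cccc(C(=O)CC2C(C#N)=C(N)Oc3ccc(Br)cc32)c1` has not yet been measured. It differs from compound 3 by hydrogen in place of methoxy on an aromatic carbon, and since the place lines of both changes agree word for word, this is the same change already seen from compound 1 to compound 2. On the strength of that earlier step, compound 4 is expected to sit higher than compound 3 in this assay, with a step estimated at a number 17.1 percentage points higher from compound 3 to compound 4 (beyond the scatter), resting on a single precedent and therefore held loosely. Compound 4 is expected to give about 73%, most likely between 56% and 89%.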

Compound 4, a percentage reported as activity, at one concentration (the size of the read-out at that concentration, not a potency): 51.2%
Estimate against measurement, compound 4: 21.8 percentage points above; the whole stated range lies above it.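

In this assay, putting hydrogen in place of methoxy on the aromatic carbon of the core shared by compound 3 and compound 4 gives a number 4.7 percentage points lower from compound 3 to compound 4 (within the scatter). The same change therefore does not carry over with the same result from one pair to the other, and the earlier step cannot be taken as a general value for this change in the series: the same change on two cores in this assay, a number 22.3 percentage points higher (beyond the scatter) from compound 1 to compound 2 and a number 4.7 percentage points lower (within the scatter) from compound 3 to compound 4, 27 percentage points apart, beyond the scatter of two such steps What this does not show is which of the other structural differences between the two pairs makes the outcome depend on its surroundings, and two pairs give no rule for any further core.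

The compounds shown leave open whether a carboxylic acid or an amide in place of the ester or the nitrile would side with one pair or the other. They also leave open how an ethoxy or a fluoro group would compare with methoxy and hydrogen on that same aromatic carbon.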